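Ether side chain: the step to compound 4

The source may report more compounds than this note shows. Statements on the series, on what has been measured and on what is new or still open speak of the compounds shown alone.

Compound 1 `COC/C1=C/C[C@](C)(CCC=C(C)C)/C=C/[C@@H](OC(=O)C=C(C)C)[C@](C)(O)/C=C/C1=O` gives 3850 nM
Compound 2 `CC(C)=CCC[C@]1(C)/C=C/[C@@H](OC(=O)C=C(C)C)[C@](C)(O)/C=C/C(=O)/C(CCl)=C\C1` gives 390 nM
Compound 3 `CC(C)=CCC[C@]1(C)/C=C/[C@@H](OC(=O)C=C(C)C)[C@](C)(O)/C=C/C(=O)/C(CN(C(C)C)C(C)C)=C\C1` gives 750 nM
Compound 4 `COCOC/C1=C/C[C@](C)(CCC=C(C)C)/C=C/[C@@H](OC(=O)C=C(C)C)[C@](C)(O)/C=C/C1=O` is not yet measured

All values come from a functional assay on SW480 cells (Homo sapiens) for antiproliferative activity, read by MTT assay, with a stated time of 48 h (a higher number here means a weaker inhibitor, a lower number a stronger inhibitor), and compound 3 sits level with compound 2 and under compound 1: a 1.9-fold higher number from compound 2 to compound 3 (0.28 log units; within the scatter) stays within the scatter, while a 5.1-fold lower number from compound 1 to compound 3 (0.71 log units; beyond the scatter) goes beyond it. The change (methoxymethoxy in place of diisopropylamino on a saturated chain carbon bound to a double-bonded ring carbon) puts methoxymethoxy in place of diisopropylamino on a saturated chain carbon bound to a double-bonded ring carbon. The nearest evidence is compound 1, also an ether at that place, where a 9.9-fold lower number from compound 1 to compound 2 (0.99 log units; beyond the scatter) and a 5.1-fold lower number from compound 1 to compound 3 (0.71 log units; beyond the scatter) are modest steps beyond the scatter. A step of similar size back upward in this assay is therefore expected. The estimate means a 4.0-fold higher number from compound 3 to compound 4 (0.60 log units; beyond the scatter) as the expected move. Compound 4 is estimated at 3000 nM (1200 nM to 7500 nM).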

Compound 4, half-maximal inhibitory concentration: 3710 nM
Compound 4: the middle estimate sits 1.2-fold (0.09 log units) below what was measured; low and high end bracket the measured number.
By their numbers in this assay, from the lowest: compounds 2 and 3 (each within the scatter of the next); then compounds 4 and 1 (each within the scatter of the next).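

Compound 1 and compound 4 now read alike (a 1.0-fold lower number from compound 1 to compound 4 (0.02 log units; within the scatter)), so the methoxy and methoxymethoxy ethers at this place give the same level of activity within the scatter. Both chloro and diisopropylamino stand clear of the methoxymethoxy ether (a 4.9-fold higher number from compound 3 to compound 4 (0.69 log units; beyond the scatter) and a 9.5-fold higher number from compound 2 to compound 4 (0.98 log units; beyond the scatter)), so the weak level is shared by the two ethers shown rather than tied to one of them. No measurement here accounts for this gap.

Open, on these data alone, is whether a hydroxyl, a primary amine or a longer ether chain at this place would read with the two ethers or with chloro and diisopropylamino.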